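The source may hold more compounds than are shown below. What is called first, only, known or untested is meant among the compounds shown, and "the series" means these compounds.

Compound 1 `O=C(/C=C/c1ccc(I)cc1)c1ccc(OCB(O)O)cc1` carries a group of 3 heavy atoms (1 boron, 2 oxygen; no ring) on a saturated chain carbon bound to an oxygen on an aromatic ring. In a functional assay on MDA-MB-435 cells (Homo sapiens) for inhibition (a higher number here means a weaker inhibitor, a lower number a stronger inhibitor), compound 1 gives 18000 nM. Compound 2 `O=C(/C=C/c1ccccc1)c1ccc[nH]1` gives 15000 nM in this assay, and compound 3 `O=C(/C=C/c1ccc(B(O)O)cc1)c1ccc[nH]1` gives 15000 nM. The three numbers lie within the scatter of one another, so compound 1 cannot be set apart from the other two on these data. Within the data shown here, the one step measured within the set, no change at the digits printed from compound 2 to compound 3 (within the scatter), adds the boron-bearing group to an aromatic carbon of the shared core without any shift in the read-out.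

Among the measured compounds shown here, compound 4 `O=C(O)COc1ccc(C(=O)/C=C/c2ccc(I)cc2)cc1` is not yet measured. a group of 3 heavy atoms (1 carbon, 2 oxygen; no ring) in place of a group of 3 heavy atoms (1 boron, 2 oxygen; no ring), on a saturated chain carbon bound to an oxygen on an aromatic ring No measured pair exchanges the boron-bearing group for a carboxy, so the change can be weighed only indirectly. Because no change at the digits printed from compound 2 to compound 3 (within the scatter) shows that adding the boron-bearing group left the read-out unchanged, that group appears to carry little weight in this assay, and its replacement is expected to give a step of no change at the digits printed from compound 1 to compound 4 (within the scatter), nothing beyond the scatter. Compound 4 is therefore estimated at 18000 nM, with a range from 7000 nM to 45000 nM.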

Compound 4, half-maximal inhibitory concentration: 18000 nM
Estimate against measurement, compound 4: no gap at the digits printed; measured number inside the range.
By their numbers in this assay, from the lowest: compounds 2, 3, 1 and 4 (each within the scatter of the next).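

In this assay, the carboxy group in place of the boron-bearing group, on a saturated chain carbon bound to an oxygen on an aromatic ring, gives no change at the digits printed from compound 1 to compound 4 (within the scatter). Among these compounds, this is the first direct exchange read at this place, whereas the earlier step, no change at the digits printed from compound 2 to compound 3 (within the scatter), concerned a boron-bearing group on an aromatic carbon in a different pair of compounds; here, the boron-bearing group can be exchanged without a shift beyond the scatter, even though the count falls from 2 hydrogen-bond donors and 2 acceptors to 1 of each. No measured property bears on this result, so the flat step has no explanation on these data.

Among the compounds shown here, with only two groups compared at this place, it remains open whether the read-out responds to any group there or whether these two simply happen to match. Going by these compounds, what an amine or a longer chain would give at this place remains unknown, and since all four compounds lie within the scatter of their neighbours in the order of their values, the series does not yet show which changes could move the number.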